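The source may report more compounds than this note shows. Statements on the series, on what has been measured and on what is new or still open speak of the compounds shown alone.

Measured in an ADME assay on CCRF-CEM cells (Homo sapiens) for cytotoxicity, read by MTT assay, with a stated time of 4 days; on this read-out lower numbers stand for higher toxicity in this test and higher numbers for lower toxicity in this test:
- Compound 1 `Cc1cc(C)cc(Cc2cc(Br)ccc2OCCn2ccc(=O)[nH]c2=O)c1`: > 200000 nM (a limit of the assay)
- Compound 2 `Cc1ccc(OCCn2ccc(=O)[nH]c2=O)c(Cc2ccccc2)c1`: 48000 nM

Within the data shown here, only two compounds have been tested so far, and just one of them gave a true number. In this assay, among the measured compounds shown here, compound 2 gives 48000 nM, the only number available. Compound 1 gives > 200000 nM, which is a limit and not a number.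

The next compound is compound 3 `Cc1cc(C)cc(Cc2cc(C)ccc2OCCn2ccc(=O)[nH]c2=O)c1`. It differs from compound 2 in one place: 3,5-dimethylphenyl in place of phenyl on a saturated chain carbon bound to an aromatic carbon. This puts 3,5-dimethylphenyl in place of phenyl on a saturated chain carbon bound to an aromatic carbon, turning benzyl into 3,5-dimethylbenzyl. For the measured compounds named here, no measured one-place step shows what this change does, so any expectation is loose. Compound 1 carries the same 3,5-dimethylbenzyl group, but it also has a bromine where compound 3 has a methyl. Given the limit of > 200000 nM for compound 1, a moderate rise in the number is expected, meaning lower toxicity in this assay. The expected change is a 2.1-fold higher number from compound 2 to compound 3 (0.32 log units; beyond the scatter). For compound 3, the estimated half-maximal cytotoxic concentration is 100000 nM, with an expected range of 35000 nM to 200000 nM.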

Compound 3, half-maximal cytotoxic concentration in the CCRF-CEM assay: 66000 nM
The estimate for compound 3 lay 1.5-fold (0.18 log units) above the measured number; the range from low to high includes it.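

In the CCRF-CEM assay, the change from benzyl to 3,5-dimethylbenzyl gives a 1.4-fold higher number from compound 2 to compound 3 (0.14 log units; within the scatter), and in a physicochemical assay for solubility (on this read-out higher numbers stand for higher solubility and lower numbers for lower solubility), the same change gives a 1.0-fold higher number from compound 2 to compound 3 (0.01 log units; within the scatter), so on a saturated chain carbon bound to an aromatic carbon this larger group leaves both read-outs within the scatter. In the physicochemical assay compound 2 gives 179000 nM and compound 3 gives 185000 nM. With 3,5-dimethylbenzyl held the same, methyl in place of bromo on an aromatic carbon gives, in the CCRF-CEM assay, an at least 3.0-fold lower number from compound 1 to compound 3 (0.48 log units; beyond the scatter), which shows that 3,5-dimethylbenzyl alone does not carry compound 3 to the level of compound 1. The size of this step is only a bound, as in the CCRF-CEM assay compound 1 gives > 200000 nM, a limit of the assay and not a number: the limit of > 200000 nM in the CCRF-CEM assay, at which 1 of the 3 values shown sits.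

The compounds shown leave open how far the read-out would move with other groups on that aromatic carbon, such as chloro, methoxy or a carboxylic acid, and so whether bromo stands apart from them. They also leave open whether an amine on the benzyl ring, or a longer chain to the shared core, would shift either read-out beyond the scatter.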